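The source may report more compounds than this note shows. Statements on the series, on what has been measured and on what is new or still open speak of the compounds shown alone.

Working notes on the series. Compound 2 `COc1ccc(Br)cc1S(=O)(=O)Nc1cncc(C(N)=O)c1` stands lowest of the two numbers recorded so far in an assay on isolated protein for inhibition of alkaline phosphatase, tissue-nonspecific isozyme (Homo sapiens) (on this read-out lower numbers stand for stronger inhibition and higher numbers for weaker inhibition), where compound 2 gives 121 nM. Its nearest neighbour is compound 1 `COc1ccc(OC(F)(F)F)cc1S(=O)(=O)Nc1cncc(C(N)=O)c1`, which in this assay gives 1560 nM; the step of a 13-fold lower number from compound 1 to compound 2 (1.11 log units; beyond the scatter) is the only one measured in this assay and is the one that bears on the next move. Compound 3 `COc1ccc(F)cc1S(=O)(=O)Nc1cncc(C(N)=O)c1` is not yet measured; it differs from compound 2 by fluoro in place of bromo on an aromatic carbon. The measured step shows that the group on this carbon sets the number over a wide span, with bromo giving the lowest value seen. Among the measured compounds shown here, with one heavy atom exchanged for one heavy atom, and no measured step for fluoro at this place, the expectation for compound 3 is a moderate rise, a 2.9-fold higher number from compound 2 to compound 3 (0.46 log units; beyond the scatter), toward the weaker side but not back to compound 1. Compound 3 is thus estimated at 350 nM, within 120 nM to 1200 nM.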

Compound 3, half-maximal inhibitory concentration: 109 nM
Estimate against measurement, compound 3: 3.2-fold (0.51 log units) above; measured number below the stated range.
By their numbers in this assay, from the lowest: compounds 3 and 2 (each within the scatter of the next); then compound 1.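

In this assay the step of fluoro in place of bromo, on the aromatic carbon para to the methoxy group, is a 1.1-fold lower number from compound 2 to compound 3 (0.05 log units; within the scatter) and so gives no separation between these two groups at this place. The step of fluoro in place of trifluoromethoxy is a 14-fold lower number from compound 1 to compound 3 (1.16 log units; beyond the scatter) and closely matches a 13-fold lower number from compound 1 to compound 2 (1.11 log units; beyond the scatter) in size. The span seen at this carbon therefore sets the single-atom groups bromo and fluoro together, with trifluoromethoxy alone on the weaker side.

Nothing at hand gives a reason for this grouping. Going by these compounds, it remains open whether plain hydrogen, methyl, a nitrile or an amine on this carbon would stay with compound 2 and compound 3 or move toward compound 1.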